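The source may report more compounds than this note shows. Statements on the series, on what has been measured and on what is new or still open speak of the compounds shown alone.

In a functional assay on MOLT-4 cells (Homo sapiens) for antiproliferative activity, with a stated time of 48 h (on this read-out lower numbers stand for stronger inhibition and higher numbers for weaker inhibition), three compounds have been measured so far
- Compound 1 `C=C(Br)C(=O)Nc1ccc(C(=O)/C=C/c2cccc(OC)c2OC)cc1` gives 490 nM
- Compound 2 `COc1ccccc1/C=C/C(=O)c1ccc(N)cc1` gives 8300 nM
- Compound 3 `COc1cccc(/C=C/C(=O)c2ccc(N)cc2)c1OC` gives 8500 nM

Compound 3 stands at the high end of these numbers, which means weak inhibition. It shares that end with compound 2, and no order can be told between the two (a 1.0-fold higher number from compound 2 to compound 3 (0.01 log units; within the scatter)). The remaining value lies far away (a 17-fold higher number from compound 1 to compound 3 (1.24 log units; beyond the scatter)).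

Compound 4 `COc1ccc(/C=C/C(=O)c2ccc(N)cc2)c(OC)c1OC` differs from compound 3 in one place, with methoxy in place of hydrogen on an aromatic carbon. Within the data shown here, the closest precedent is the measured step that added a methoxy in place of hydrogen on an aromatic carbon (a 1.0-fold higher number from compound 2 to compound 3 (0.01 log units; within the scatter)). That change left the number within the scatter. The large step (a 17-fold higher number from compound 1 to compound 3 (1.24 log units; beyond the scatter)) concerns a group on a nitrogen, a different kind of change, so it says little here. Among the measured compounds shown here, no measurement yet shows what a methoxy does at the new place, so the precedent is only one step and the range must stay wide.

No step beyond the scatter is therefore expected in this assay, and the expected step is small (a 1.1-fold lower number from compound 3 to compound 4 (0.03 log units; within the scatter)). For compound 4 the estimate is 8000 nM, with an expected range from 3000 nM to 20000 nM.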

Compound 4, half-maximal inhibitory concentration: 10000 nM
Beside the measured number, compound 4's estimate is 1.3-fold (0.10 log units) below it; the measured number falls inside the stated range.
By their numbers in this assay, from the lowest: compound 1; then compounds 2, 3 and 4 (each within the scatter of the next).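

In this assay, a methoxy at this new place, ortho to a methoxy group, meta to a methoxy group and para to a large group, gives a 1.2-fold higher number from compound 3 to compound 4 (0.07 log units; within the scatter). The earlier methoxy change gave a 1.0-fold higher number from compound 2 to compound 3 (0.01 log units; within the scatter), so there are now two such changes on this aromatic ring, at different places, and neither moves the number beyond the scatter. In this short series, adding methoxy groups has not recovered the much stronger inhibition tied to the group on the nitrogen, seen in a 17-fold higher number from compound 1 to compound 3 (1.24 log units; beyond the scatter), and no supporting measurement offers an explanation for the flat result.

The compounds shown leave open whether a different group at this place, such as a hydroxy group, a fluorine atom or an amine, would shift the number beyond the scatter. Among these compounds, they also leave open whether placing the (1-bromoethenyl)carbonyl group on the nitrogen of compound 4 would bring a gain as large as the one that group brings to the core of compound 3.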